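Bromo to methyl on compound 2

A few compounds are considered here, and "the series" means these few. Any claim that something is new, unique, unknown or untested is made for them only; others in the source may bear on it.

In a functional assay on MCF7 cells (Homo sapiens) for cytotoxicity, read by MTT assay, with a stated time of 72 h (a higher number here means a weaker inhibitor, a lower number a stronger inhibitor), compound 2 `CNC(=O)c1cc(Oc2ccc(/C=C/C(=O)c3ccc(Br)cc3)cc2)ccn1` gives 7100 nM, and compound 1 `CNC(=O)c1cc(Oc2ccc(C(=O)/C=C/c3cccc(Br)c3)cc2)ccn1` gives 10400 nM. These two values lie within the usual scatter of each other, so neither compound can be ranked ahead of the other. Compound 3 `CNC(=O)c1cc(Oc2ccc(C(=O)/C=C/c3cccc([N+](=O)[O-])c3)cc2)ccn1` is reported as > 50000 nM, which is a limit of the assay and not a number.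

The unmeasured compound 4 `CNC(=O)c1cc(Oc2ccc(/C=C/C(=O)c3ccc(C)cc3)cc2)ccn1` differs from compound 2 in one place: methyl in place of bromo on an aromatic carbon.

Going by the values given here, the one measured step that replaces a bromo is an at least 4.8-fold higher number from compound 1 to compound 3 (0.68 log units; beyond the scatter), with nitro in place of bromo on an aromatic carbon. It shows that such a swap can move the number in this assay, but it is only a loose guide, since it starts from a different compound and brings in nitro rather than methyl. A smaller move in the same direction, towards a higher number, therefore seems likely, and it may not clear the scatter. The expected change is a 1.4-fold higher number from compound 2 to compound 4 (0.15 log units; within the scatter). For compound 4 the estimate is 10000 nM, with an expected range of 4000 nM to 26000 nM.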

Compound 4, half-maximal inhibitory concentration: 24900 nM
Beside the measured number, compound 4's estimate is 2.5-fold (0.40 log units) below it, within the range that was stated.
By their numbers in this assay, from the lowest: compounds 2 and 1 (each within the scatter of the next); then compound 4. At a limit, above all of these: compound 3.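

In this assay, methyl in place of bromo gives a 3.5-fold higher number from compound 2 to compound 4 (0.54 log units; beyond the scatter), so on this 4-bromophenyl group the swap moves the number by more than the usual scatter, towards a weaker inhibitor. Bromo and methyl each count as 1 heavy atom, with no ring and no net charge, so a change that leaves these counts the same can still shift the result in this assay. This step also has a measured number at both ends, whereas compound 3 stands at a limit, which is not a number, and the earlier replacement of bromo therefore has no exact size: the limit of > 50000 nM in this assay, at which 1 of the 4 values shown sits.

As far as these compounds go, whether this result is specific to bromo remains open, as a single replacement cannot show how other groups at this place, such as chloro, methoxy or an amine, would compare. From the compounds shown here alone, it also remains open whether methyl in place of bromo on compound 1 would move the number as far.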